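Compound 4 and the limits around compound 3

A few compounds are considered here, and "the series" means these few. Any claim that something is new, unique, unknown or untested is made for them only; others in the source may bear on it.

Compound 1 `COC(=O)c1cc(-c2cccc(NC(=O)c3ccc(OCc4ccc(Cl)cc4)cc3)c2)on1`: > 80 ug/mL
Compound 2 `COC(=O)c1cc(-c2cccc(NC(=O)c3ccc(/C=C/C(=O)c4ccc(OC)cc4OC)cc3)c2)on1`: > 50 ug/mL
Compound 3 `COC(=O)c1cc(-c2cccc(NC(=O)c3ccc(/C=C/C(=O)c4ccc(Cl)cc4Cl)cc3)c2)on1`: > 40 ug/mL

In an ADME assay on Vero cells (Chlorocebus sabaeus) for cytotoxicity, read by MTT assay, with a stated time of 72 h (on this read-out lower numbers stand for higher toxicity in this test and higher numbers for lower toxicity in this test), compound 1 reports only a limit. For compound 2 the result is likewise a limit. Compound 3 also stands at a limit, namely (the limit of > 40 ug/mL in this assay, at which 1 of the 3 values shown sits), so its true value is not known. The two measured steps, a step that the two limits leave unreadable from compound 1 to compound 3 and a step that the two limits leave unreadable from compound 2 to compound 3, are therefore unreadable. Compound 4 `COC(=O)c1cc(-c2cccc(NC(=O)c3ccc(/C=C/C(=O)c4ccccc4C)cc3)c2)on1` differs from compound 3 by 2-methylphenyl in place of 2,4-dichlorophenyl on a carbonyl carbon. Going by the values given here, no measured step bears on this change, and no direction beyond the scatter can be expected in this assay. Compound 4 is therefore expected to sit near the limit range again, with the step that the limit leaves unreadable from compound 3 to compound 4 as an estimate only. The estimated value for compound 4 is 60 ug/mL, ranging from 30 ug/mL to 150 ug/mL.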

Compound 4, half-maximal cytotoxic concentration: > 25 ug/mL
Compound 4 was reported as a limit; the forecaster's own chance of this, stated with the estimate: 75%; the middle value does not contradict the limit.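

In this assay compound 4 also gives only a limit, > 25 ug/mL. Going by these compounds alone, no step from compound 1, compound 2 or compound 3 to compound 4 can therefore be read. The compounds shown leave open the true values of all four compounds, and whether 2-methylphenyl changes this read-out at all.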